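Methoxy to Hydroxy on an Otherwise Unchanged Scaffold

The source may report more compounds than this note shows. Statements on the series, on what has been measured and on what is new or still open speak of the compounds shown alone.

Going by the values given here, compound 2 `COc1cc(-c2nn(-c3cccc(NC(=O)Nc4ccc(Cl)c(C(F)(F)F)c4)c3)cc2-c2ccncc2)ccc1Cl` gives 1180 nM in a functional assay on RXF 393 cells (Homo sapiens) for inhibition, read by sulforhodamine B assay, with a stated time of 48 h (a lower number here means a stronger inhibitor of growth, a higher number a weaker inhibitor of growth), the numerically higher of only two values, a difference that itself lies within the scatter. Among the compounds with values here, compound 1 `COc1cc(-c2nn(-c3cccc(NC(=O)c4cccc(C(F)(F)F)c4)c3)cc2-c2ccncc2)ccc1Cl` gives 811 nM, and the single recorded step, a 1.5-fold higher number from compound 1 to compound 2 (0.16 log units; within the scatter), concerns the amide side of the molecule. Compound 3 `O=C(Nc1cccc(-n2cc(-c3ccncc3)c(-c3ccc(Cl)c(O)c3)n2)c1)Nc1ccc(Cl)c(C(F)(F)F)c1` differs from compound 2 by hydrogen in place of methyl on an oxygen on an aromatic ring, that is methoxy to hydroxy. Within the data shown here, no measured step touches this oxygen, so for compound 3 the expected step is a 1.0-fold higher number from compound 2 to compound 3 (0.01 log units; within the scatter), nothing beyond the scatter. Compound 3 is therefore estimated to give 1200 nM, within 400 nM to 3600 nM.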

Compound 3, concentration for 50% growth inhibition: 508 nM
Estimate against measurement, compound 3: 2.4-fold (0.37 log units) above; measured number inside the range.
By their numbers in this assay, from the lowest: compounds 3, 1 and 2 (each within the scatter of the next, the first and the last beyond it).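

In this assay, going by these compounds alone, the change from methoxy to hydroxy gives a 2.3-fold lower number from compound 2 to compound 3 (0.37 log units; beyond the scatter) and so shows that this oxygen on an aromatic ring is a place where one small change registers, which the single earlier step, lying within the scatter, did not show for any position. Nothing measured here bears on why the number falls. Going by these compounds, whether an amine, an ethoxy or a carboxylic acid in place of the hydroxy would do the same stays open, as does whether hydroxy gives a similar step on the amide side of compound 1.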